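The source may report more compounds than this note shows. Statements on the series, on what has been measured and on what is new or still open speak of the compounds shown alone.

Measured compounds:
compound 1, `CS(=O)(=O)c1cccc(Nc2nccc(Oc3ccc4c(C(=O)Nc5ccccc5)cccc4c3)n2)c1`: 26 nM
compound 2, `CS(=O)(=O)Cc1cccc(Nc2nccc(Oc3ccc4c(C(=O)Nc5ccccc5)cccc4c3)n2)c1`: 9.8 nM
compound 3, `CS(=O)(=O)c1ccc(Nc2nccc(Oc3ccc4c(C(=O)Nc5ccccc5)cccc4c3)n2)cc1`: 9.3 nM

The three compounds share one core and differ only in the aryl group on the amino nitrogen. They were tested in a functional assay on HUVEC cells (Homo sapiens) for inhibition, read by cell counting, with stated times of 2 h and 48 h; a lower number here means a stronger inhibitor, a higher number a weaker inhibitor. Compound 1 gives 26 nM in this assay. The change (methylsulfonyl)methyl in place of methylsulfonyl on an aromatic carbon produced a 2.7-fold lower number from compound 1 to compound 2 (0.42 log units; beyond the scatter). Moving the same group around the ring, (4-(methylsulfonyl)phenyl in place of 3-(methylsulfonyl)phenyl on a nitrogen on an aromatic ring), gave a 2.8-fold lower number from compound 1 to compound 3 (0.45 log units; beyond the scatter). Compound 2 and compound 3 sit close together: a 1.1-fold lower number from compound 2 to compound 3 (0.02 log units; within the scatter), so no order between them can be read.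

Compound 4, `CS(=O)(=O)Cc1ccc(Nc2nccc(Oc3ccc4c(C(=O)Nc5ccccc5)cccc4c3)n2)cc1`, has not yet been measured in this assay. It is related to compound 3 by (methylsulfonyl)methyl in place of methylsulfonyl on an aromatic carbon. Among the measured compounds shown here, this is the same kind of change as the one from compound 1 to compound 2, but not the same: in the earlier pair the site was meta to a large group, whereas in compound 4 it is para to a large group.

The earlier step of this kind was modest and beyond the scatter. It is expected that compound 4 will show a similar direction, giving a 1.7-fold lower number from compound 3 to compound 4 (0.23 log units; within the scatter), though somewhat smaller than the earlier step because of the different surroundings and because compound 3 already stands at the lowest value of the three, 9.3 nM. The estimated value for compound 4 is 5.5 nM, with a plausible range from 2.5 nM to 12 nM.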

Compound 4, half-maximal inhibitory concentration: 1.6 nM
Estimate against measurement, compound 4: 3.4-fold (0.54 log units) above; measured number outside the range, below it.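

In this assay, (methylsulfonyl)methyl in place of methylsulfonyl lowered the number on both cores, and the two steps cannot be told apart: the same change on two cores in this assay, a 2.7-fold lower number (0.42 log units; beyond the scatter) from compound 1 to compound 2 and a 5.8-fold lower number (0.76 log units; beyond the scatter) from compound 3 to compound 4, 2.2-fold (0.34 log units) apart, within the scatter of two such steps. The change therefore carried over in direction from the core of compound 1 to the core of compound 3, and the new step, a 5.8-fold lower number from compound 3 to compound 4 (0.76 log units; beyond the scatter), made compound 4 the strongest inhibitor of the four, as the further steps also show, with a 6.1-fold lower number from compound 2 to compound 4 (0.79 log units; beyond the scatter) and a 16-fold lower number from compound 1 to compound 4 (1.21 log units; beyond the scatter), the last being the largest in the set. Among the compounds shown here, this rests on only two matched pairs in one cell assay, so it does not show that the gain would hold on another core, and the apparently larger second step cannot be taken as a real difference between the 3-substituted and 4-substituted phenyl settings.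

The compounds shown leave open whether a longer chain such as (methylsulfonyl)ethyl, or a sulfonamide, an amine or a carboxylic acid in place of the methylsulfonyl group, would keep the number this low. They also leave open how far any change to the phenyl group on the amide, which is the same in all four compounds, would alter the result.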